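A few compounds are considered here, and "the series" means these few. Any claim that something is new, unique, unknown or untested is made for them only; others in the source may bear on it.

Compound 1 `O=C(CCl)N1CCCC(n2nc(-c3ccc(Oc4ccccc4)cc3)cc2CO)C1` gives the lowest number of the three measured compounds in a functional assay on Z-138 cells (Homo sapiens) for inhibition, read by luminescence and CellTiter-Glo, with a stated time of 72 h (on this read-out higher numbers stand for weaker inhibition and lower numbers for stronger inhibition), at 400 nM. Within the data shown here, compound 2 `C/C=C/C(=O)N1CCCC(n2nc(-c3ccc(Oc4ccccc4)cc3)cc2CO)C1` gives 51100 nM and compound 3 `C=CC(=O)N1CCCC(n2nc(-c3ccc(Oc4ccccc4)cc3)cc2CO)C1` gives 14600 nM; the only steps measured so far, a 130-fold higher number from compound 1 to compound 2 (2.11 log units; beyond the scatter) and a 37-fold higher number from compound 1 to compound 3 (1.56 log units; beyond the scatter), concern the group on the carbonyl carbon and are both large. Compound 4 `O=C(O)c1cc(-c2ccc(Oc3ccccc3)cc2)nn1C1CCCN(C(=O)CCl)C1` keeps the chloromethyl on the carbonyl carbon and differs from compound 1 elsewhere: carboxy in place of hydroxymethyl on an aromatic carbon. Among the measured compounds shown here, no measured step touches this position, so no direction can be taken from the data; a change small enough to sit near the scatter is expected, with some room for a weaker result. Compound 4 is therefore estimated at 800 nM (range 200 nM to 4000 nM), an expected step of a 2.0-fold higher number from compound 1 to compound 4 (0.30 log units; within the scatter).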

Compound 4, half-maximal inhibitory concentration: 2800 nM
The estimate for compound 4 lay 3.5-fold (0.54 log units) below the measured number, within the range that was stated.
By their numbers in this assay, from the lowest: compound 1; then compound 4; then compound 3; then compound 2.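

The aromatic carbon next to the ring atom bearing the 1-((chloromethyl)carbonyl)piperidin-3-yl group is not a silent position: in this assay, carboxy in place of hydroxymethyl gives a 7.0-fold higher number from compound 1 to compound 4 (0.85 log units; beyond the scatter), beyond the scatter. Among these compounds, this is the first measured change away from the carbonyl carbon, and it shows that the number responds to this position with chloromethyl held constant. No evidence on hand gives a cause for this step.

Still open, on these data alone, is how a primary amide, an amine or a methyl ester on this carbon would read. Also open, as far as these compounds go, is whether the carboxy step carries over when vinyl sits on the carbonyl carbon.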